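Benzyl in place of methyl on the shared core

The source may hold more compounds than are shown below. What is called first, only, known or untested is meant among the compounds shown, and "the series" means these compounds.

Among the measured compounds shown here, compound 2 `Cn1ncc2cc(C(=N)Nc3cccc(C(F)(F)F)c3)ncc21` is the only one with a number in a functional assay on PC-3 cells (Homo sapiens) for cytotoxicity, read by MTT assay, with a stated time of 72 h (on this read-out lower numbers stand for stronger inhibition and higher numbers for weaker inhibition), where compound 2 gives 50000 nM. Compound 1 `N=C(Nc1cccc(C(F)(F)F)c1)c1cc2cn[nH]c2cn1` reaches only the limit of this assay, > 50000 nM. For the measured compounds named here, the single measured step, a number no higher from compound 1 to compound 2 (the limit leaves the size open), rests on that limit of > 50000 nM in this assay, at which 1 of the 2 values shown sits, and gives no readable size. Compound 3 `COc1ccc(Cn2ncc3cc(C(=N)Nc4cccc(C(F)(F)F)c4)ncc32)cc1` differs from compound 2 by 4-methoxyphenyl in place of hydrogen on a saturated chain carbon bound to an aromatic nitrogen. Going by the values given here, no measured step bears on this change, so no shift beyond the scatter is expected. Compound 3 is estimated at 30000 nM, within 5000 nM to 50000 nM. The expected step is therefore a 1.7-fold lower number from compound 2 to compound 3 (0.22 log units; within the scatter).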

Compound 3, half-maximal inhibitory concentration: 27600 nM
For compound 3 the middle estimate is 1.1-fold (0.04 log units) above the measured one, and the stated range covers the measured number.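

In this assay, 4-methoxyphenyl on a saturated chain carbon bound to an aromatic nitrogen gives a 1.8-fold lower number from compound 2 to compound 3 (0.26 log units; within the scatter), so this position carries a six-membered aromatic ring with no shift beyond the scatter. Replacing hydrogen on the aromatic nitrogen with 4-methoxybenzyl gives an at least 1.8-fold lower number from compound 1 to compound 3 (0.25 log units; that floor lies within the scatter). That floor rests on compound 1, whose value is a limit and not a number: the limit of > 50000 nM in this assay, at which 1 of the 3 values shown sits.

The compounds shown leave open whether an amine or a carboxylic acid in place of the methoxy group of compound 3 would move the number beyond the scatter.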